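Trimming an isopropyl group to ethyl in compound 2

The source may report more compounds than this note shows. Statements on the series, on what has been measured and on what is new or still open speak of the compounds shown alone.

Measured so far in a functional assay on the whole organism (Abdomen) with Mus musculus as the target; on this read-out lower numbers stand for an effect already at smaller amounts and higher numbers for an effect only at larger amounts of compound:

- compound 1 `CCCc1nc(Cc2c[nH]cn2)c(CCC)s1` gives 30 mg/kg
- compound 2 `CC(C)c1nc(Cc2c[nH]cn2)c(C(C)C)s1` gives 23.8 mg/kg
- compound 3 `CCc1sc(C(C)C)nc1Cc1c[nH]cn1` gives 7.5 mg/kg

Compound 2 and compound 1 lie within the usual scatter of each other, while compound 3 sits clearly lower than both. Compound 4 `CCc1nc(Cc2c[nH]cn2)c(C(C)C)s1` differs from compound 2 in one place: hydrogen in place of methyl on a saturated chain carbon bound to an aromatic carbon and a saturated chain carbon (hydrogen in place of methyl on a saturated chain carbon bound to an aromatic carbon and a saturated chain carbon, which reads as isopropyl to ethyl).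

For the measured compounds named here, one measured step bears on this. The same kind of change, made at a different isopropyl group of compound 2, gave a 3.2-fold lower number from compound 2 to compound 3 (0.50 log units; beyond the scatter) and so went beyond the scatter. That is a single example from another place on the shared core, so it supports the direction better than the size. A somewhat smaller drop is therefore expected in this assay here. The estimate is a 2.0-fold lower number from compound 2 to compound 4 (0.30 log units; within the scatter) as the expected step. The expected value for compound 4 is 12 mg/kg with an estimated range from 5 mg/kg to 28 mg/kg for the measurement.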

Compound 4, dose for half-maximal effect: 25.3 mg/kg
Compound 4: the middle estimate sits 2.1-fold (0.32 log units) below what was measured; low and high end bracket the measured number.
By their numbers in this assay, from the lowest: compound 3; then compounds 2, 4 and 1 (each within the scatter of the next).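

In this assay, trimming this isopropyl group to ethyl gives a 1.1-fold higher number from compound 2 to compound 4 (0.03 log units; within the scatter), so the change makes no difference that can be told from the usual scatter. The same trimming at the other isopropyl group of compound 2 gave a 3.2-fold lower number from compound 2 to compound 3 (0.50 log units; beyond the scatter), which lies beyond the scatter, so in these two examples the outcome of the change depends on which isopropyl group is trimmed. Nothing available explains why the two groups behave differently.

From the compounds shown here alone, only isopropyl and ethyl can be compared at this place, so it stays open whether a smaller methyl, a longer butyl chain or an amine there would shift the number in this assay. Each place also rests on a single step, which leaves the generality of this contrast open.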